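This account rests on a few compounds, and the source may have more. Where it says the series, first, only, none or still open, it means among the compounds named here.

Compound 3 `COc1ccc(-c2nc(C(C)S(=O)(=O)c3cccc(Cl)c3)nc3ccsc23)cn1` is the starting point of this step. In an ADME assay on cells (Homo sapiens) for cytotoxicity, read by resazurin assay, with a stated time of 5 days (a lower number here means that less compound is tolerated, a higher number that more compound is tolerated), compound 3 gives > 50000 nM, which is a limit of the assay and not a number. Compound 1 `COc1ccc(-c2nc(C(C)(C)S(=O)(=O)c3cccc(Cl)c3)nc3ccsc23)cn1`, built on the same core, also reaches only a limit in this assay, where compound 1 gives > 50000 nM. Compound 2 `CCC1=C(C(=O)OCC2CCCCC2)C(c2cccc(O)c2)NC(=O)N1`, on a different core, likewise sits at a limit in this assay, where compound 2 gives > 10000 nM. Within the data shown here, two of the three values thus sit at the limit of > 50000 nM in this assay, at which 2 of the 3 values shown sit, and one at the limit of > 10000 nM in this assay, at which 1 of the 3 values shown sits; no compound of the series has so far produced a readable number. Among the measured compounds shown here, the single measured step, a step that the two limits leave unreadable from compound 1 to compound 3, cannot be read in size or direction, since both of its ends are limits.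

Compound 4 `COc1ccc(-c2nc(CS(=O)(=O)c3cccc(Cl)c3)nc3ccsc23)cn1` is not yet measured. Relative to compound 3 it shows (hydrogen in place of methyl on a saturated chain carbon bound to an aromatic carbon and a sulfonyl sulfur). For the measured compounds named here, the step from compound 1 to compound 3 is the only precedent for removing a methyl at this place, and it supplies neither a size nor a direction. No step beyond the scatter is expected in this assay, and compound 4 is expected to return once more a limit rather than a number. The step that the limit leaves unreadable from compound 3 to compound 4 is therefore expected to be flat. For compound 4 in this assay the estimate is 60000 nM, within 25000 nM to 200000 nM.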

Compound 4, half-maximal cytotoxic concentration: > 10000 nM
Compound 4: only a limit was reported; the forecaster's own chance of this, stated with the estimate: 85%; the middle value does not contradict the limit.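

The step from compound 3 to compound 4 in this assay cannot be read, since both compounds return only limits of the assay and not numbers. The compounds shown leave open whether hydrogen in place of methyl at this chain carbon shifts the tolerated concentration at all, as none of them gives a readable value.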